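A few compounds are considered here, and "the series" means these few. Any claim that something is new, unique, unknown or untested is made for them only; others in the source may bear on it.

The series shares a piperidine sulfonamide core and differs in the aryl group on the sulfonyl sulfur. Compound 1 `Cc1cc(Cl)cc(Cl)c1S(=O)(=O)N1CCC(N2CCC(C)CC2)CC1` gives 0.6 nM in a functional assay on DLD-1 cells (Homo sapiens) for antiproliferative activity, read by CellTiter-Glo, with a stated time of 72 h; a lower number here means a stronger inhibitor, a higher number a weaker inhibitor. Compound 2 `Cc1cc(C)c(S(=O)(=O)N2CCN(C3CN4CCC3CC4)CC2)c(C)c1`, which carries a different amine and a trimethylphenyl group, gives 84 nM in this assay. Compound 3 `CC1CCN(C2CCN(S(=O)(=O)c3cccnc3Cl)CC2)CC1` is the weakest of the three shown: in this assay compound 3 returns only a limit, > 5000 nM, which is the point at which (the limit of > 5000 nM in this assay, at which 1 of the 3 values shown sits). Compound 4 `CC1CCN(C2CCN(S(=O)(=O)c3ccccc3Br)CC2)CC1` has not yet been measured. It differs from compound 3 in one place: 2-bromophenyl in place of 2-chloropyridin-3-yl on a sulfonyl sulfur. The arene that enters resembles the carbon-only ring of compound 1, which gave 0.6 nM, more than the ring of compound 3 does, so a move toward stronger inhibition is expected for compound 4, though the size of this move is uncertain because compound 3 sits at > 5000 nM, a limit rather than a number. Compound 4 is estimated to reach 300 nM in this assay, within a range of 30 nM to 5000 nM. The expected step from compound 3 to compound 4 is therefore an at least 16-fold lower number from compound 3 to compound 4 (1.22 log units; beyond the scatter), an improvement beyond the scatter, while a further limit remains possible.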

Compound 4, half-maximal inhibitory concentration: 3 nM
For compound 4 the middle estimate is 100-fold (2.00 log units) above the measured one, outside the stated range (below it).
By their numbers in this assay, from the lowest: compound 1; then compound 4; then compound 2. At a limit, above all of these: compound 3.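

The exchange of 2-chloropyridin-3-yl for 2-bromophenyl on a sulfonyl sulfur gives an at least 1600-fold lower number from compound 3 to compound 4 (3.22 log units; beyond the scatter) in this assay. Within the data shown here, this is the first step that can be read between two compounds differing in one place, and it shows that the aryl group at this sulfonyl sulfur can, with the rest of the molecule unchanged, separate a compound at the limit of the assay from one with a low-nanomolar value. The true size of the step remains unknown, and the printed figure is only a minimum, because compound 3 stands at a limit and not at a number: the limit of > 5000 nM in this assay, at which 1 of the 4 values shown sits.

The change replaces the ring nitrogen and the chlorine together, so this pair cannot say which of the two carries the step; a phenyl group bearing a single chlorine, or a pyridine ring bearing bromine, would separate them on this core. As far as these compounds go, how a nitrile, a methoxy group or a methyl group in place of the bromine would read in this assay also remains open.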